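Extending an Aryl Ether on a Shared Core

A few compounds are considered here, and "the series" means these few. Any claim that something is new, unique, unknown or untested is made for them only; others in the source may bear on it.

Of the compounds shown here, two of one series have so far been measured in a functional assay on DU-145 cells (Homo sapiens) for cytotoxicity, read by MTT assay, with a stated time of 48 h; on this read-out higher numbers stand for weaker inhibition and lower numbers for stronger inhibition. Compound 1 `CCOC(=O)c1c(-c2cc3ccccc3oc2=O)nn(-c2ccccc2)c1C(=O)OCC` gives 57000 nM. Compound 2 `CCOC(=O)c1c(-c2cc3ccc(OC)cc3oc2=O)nn(-c2ccccc2)c1C(=O)OCC`, which carries a methoxy group in place of a hydrogen on an aromatic carbon, gives 33000 nM in this assay. Among the measured compounds shown here, the two numbers are separated only by the step of a 1.7-fold lower number from compound 1 to compound 2 (0.24 log units; within the scatter), which is the sole measured step in the set and lies within the usual scatter, so compound 2 and compound 1 stand together on this read-out rather than apart.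

Compound 3 `CCOC(=O)c1c(-c2cc3ccc(OCC=C(C)C)cc3oc2=O)nn(-c2ccccc2)c1C(=O)OCC` has not yet been measured. It differs from compound 2 by 2-methylprop-1-en-1-yl in place of hydrogen on a saturated chain carbon bound to an oxygen on an aromatic ring. For the measured compounds named here, the only measured step that bears on this change is the one from hydrogen to methoxy at the same aromatic position, and because that step a 1.7-fold lower number from compound 1 to compound 2 (0.24 log units; within the scatter) stayed within the scatter, nothing in the measured set points to a change beyond the scatter when the ether is extended further. Compound 3 is therefore expected to give 25000 nM in this assay, with a range from 8000 nM to 80000 nM. The expected step of a 1.3-fold lower number from compound 2 to compound 3 (0.12 log units; within the scatter) is thus no more than the scatter itself.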

Compound 3, half-maximal inhibitory concentration: 75000 nM
Compound 3: middle estimate off by 3.0-fold (0.48 log units), on the low side, and the stated range covers the measured number.
By their numbers in this assay, from the lowest: compounds 2, 1 and 3 (each within the scatter of the next, the first and the last beyond it).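

In this assay, among the compounds shown here, extending the methoxy group of compound 2 to the (3-methylbut-2-en-1-yl)oxy group of compound 3 gives the first step in the set that passes the scatter (a 2.3-fold higher number from compound 2 to compound 3 (0.36 log units; beyond the scatter)), a modest one towards weaker inhibition. For the compounds shown here, measured against hydrogen on the aromatic carbon, the same ether does not stand apart (a 1.3-fold higher number from compound 1 to compound 3 (0.12 log units; within the scatter)), so hydrogen lies within the scatter of both ethers and only the two ethers are separated from each other, which the first pair of compounds could not show. Nothing in the data shown accounts for this step.

The compounds shown leave open whether the step follows from the added carbon chain or from its double bond, since a saturated 3-methylbutyl ether would be needed to separate the two, and an ethyl ether would show how the numbers run between methoxy and the longer group. They also leave open how this position responds to a chain ending in an amine or a carboxylic acid.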